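Working notes: replacing methoxy with nitro

A few compounds are considered here, and "the series" means these few. Any claim that something is new, unique, unknown or untested is made for them only; others in the source may bear on it.

Measured in a functional assay on OVCAR-3 cells (Homo sapiens) for inhibition, read by sulforhodamine B assay, with a stated time of 48 h; a higher number here means a weaker inhibitor of growth, a lower number a stronger inhibitor of growth:
- compound 1 `CC(C)(C)NCc1c(C(=O)O)nn(-c2ccc(Cl)cc2)c1-c1ccc(Br)cc1`: 513000 nM
- compound 2 `COc1ccc(-c2c(CNC(C)(C)C)c(C(=O)O)nn2-c2ccc(Cl)cc2)cc1`: 121000 nM

Among the measured compounds shown here, compound 2 stands lowest of the two numbers so far. The next structure is compound 3 `CC(C)(C)NCc1c(C(=O)O)nn(-c2ccc(Cl)cc2)c1-c1ccc([N+](=O)[O-])cc1`, which differs from compound 2 as follows: nitro in place of methoxy on an aromatic carbon. In short, this is nitro in place of methoxy on an aromatic carbon, para to a large group. For the measured compounds named here, one measured step bears on it: a 4.2-fold lower number from compound 1 to compound 2 (0.63 log units; beyond the scatter). Going by the values given here, that step is modest but beyond the scatter, and it is the only measured change involving methoxy. Among the compounds with values here, no measured compound carries nitro, so the evidence is thin. A modest step towards a higher number in this assay is expected, as compound 2 at 121000 nM is the lowest so far. The expected step is a 2.3-fold higher number from compound 2 to compound 3 (0.36 log units; beyond the scatter). For compound 3 the estimated value is 280000 nM, with an expected range of 90000 nM to 800000 nM.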

Compound 3, concentration for 50% growth inhibition: 162000 nM
Estimate against measurement, compound 3: 1.7-fold (0.24 log units) above; measured number inside the range.
By their numbers in this assay, from the lowest: compounds 2 and 3 (each within the scatter of the next); then compound 1.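

In this assay, the change from 4-methoxyphenyl to 4-nitrophenyl, on an aromatic carbon para to a large group, gives a 1.3-fold higher number from compound 2 to compound 3 (0.13 log units; within the scatter) and so leaves compound 2 and compound 3 indistinguishable at this position. Against the bromo group, nitro gives a 3.2-fold lower number from compound 1 to compound 3 (0.50 log units; beyond the scatter) and thus a second replacement of bromo, after methoxy, that separates from compound 1 by more than the scatter, though only modestly. No measurement on hand accounts for why these two groups read alike or why compound 1 stands apart.

The compounds shown leave open whether an amino group or a plain hydrogen at this aromatic carbon would read with compound 2 and compound 3 or with compound 1. Also open, on these data alone, is whether an amide in place of the carboxylic acid on the shared core would move the number further than any change at this position.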